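The source may report more compounds than this note shows. Statements on the series, on what has been measured and on what is new or still open speak of the compounds shown alone.

Compound 2 `Cc1nnc(NS(=O)(=O)c2ccc(N/C=C\C(=O)c3cc4ccccc4oc3=O)cc2)s1` carries a sulfonamide whose nitrogen bears a 5-methyl-1,3,4-thiadiazol-2-yl group. Within the data shown here, in a functional assay on T47D cells (Homo sapiens) for cytotoxicity, read by sulforhodamine B assay, with a stated time of 48 h (on this read-out higher numbers stand for weaker inhibition and lower numbers for stronger inhibition), compound 2 gives 94000 nM, the highest of the two numbers measured so far. Its nearest neighbour is compound 1 `Cc1noc(NS(=O)(=O)c2ccc(N/C=C\C(=O)c3cc4ccccc4oc3=O)cc2)c1C`, which in this assay gives 68400 nM; the step of a 1.4-fold higher number from compound 1 to compound 2 (0.14 log units; within the scatter) lies within the scatter.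

Compound 3 `Cc1ccnc(NS(=O)(=O)c2ccc(N/C=C\C(=O)c3cc4ccccc4oc3=O)cc2)n1` is the next variation at the same place: 4-methylpyrimidin-2-yl in place of 5-methyl-1,3,4-thiadiazol-2-yl on a sulfonamide nitrogen. Among the measured compounds shown here, the only measured step, from compound 1 to compound 2, also exchanged the ring on the sulfonamide nitrogen and moved the number within the scatter. That step, however, compared two five-membered rings, whereas here a six-membered ring enters, so the comparison is loose.

On this basis the expected step is a 1.1-fold lower number from compound 2 to compound 3 (0.04 log units; within the scatter), not beyond the scatter. For compound 3 the estimated value in this assay is 85000 nM, with a range from 30000 nM to 250000 nM.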

Compound 3, half-maximal inhibitory concentration: 24500 nM
For compound 3 the middle estimate is 3.5-fold (0.54 log units) above the measured one; the whole stated range lies above it.
By their numbers in this assay, from the lowest: compound 3; then compounds 1 and 2 (each within the scatter of the next).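

In this assay the exchange of ring on the sulfonamide nitrogen proves able to move the number beyond the scatter: 4-methylpyrimidin-2-yl gives a 3.8-fold lower number from compound 2 to compound 3 (0.58 log units; beyond the scatter) and also a 2.8-fold lower number from compound 1 to compound 3 (0.45 log units; beyond the scatter) in the same direction. Compound 3 therefore stands apart from both compounds with a five-membered ring, and it is the strongest of the three. The position is thus not indifferent to which ring it carries, although a single six-membered example cannot show which feature of that ring matters.

Open, on these data alone, is whether the methyl group on the pyrimidine takes part, which a plain pyrimidin-2-yl or a 4,6-dimethylpyrimidin-2-yl group, or a pyridin-2-yl ring, would help to settle. Nothing measured here accounts for the change in the number.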